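The source may hold more compounds than are shown below. What is called first, only, known or untested is meant among the compounds shown, and "the series" means these compounds.

Measured compounds in the series:

compound 1 `CCOC(=O)C(=Cc1c(-c2ccccc2)[nH]c2ccccc12)C(=O)OCC` — 3800 nM
compound 2 `O=C(/C(=C\c1c(-c2ccccc2)[nH]c2ccccc12)S(=O)(=O)c1ccccc1)c1ccccc1` — 39500 nM
compound 3 `COc1ccc(-c2[nH]c3ccc(OC)cc3c2/C=C(\C#N)S(=O)(=O)c2ccccc2)cc1` — 538 nM

In a functional assay on Hs-578T cells (Homo sapiens) for inhibition, read by sulforhodamine B assay, with a stated time of 48 h (on this read-out lower numbers stand for stronger inhibition of growth and higher numbers for weaker inhibition of growth), compound 2 gives 39500 nM, the highest number of the three. Compound 1 gives 3800 nM, a lower number by an amount beyond the usual scatter, and compound 3 gives 538 nM, lower still and well beyond the scatter. No pair among these three differs in only one place, so none of the gaps can be tied to a single structural change.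

Compound 4 `N#C/C(=C\c1c(-c2ccccc2)[nH]c2ccccc12)S(=O)(=O)c1ccccc1` has not been measured in this assay. Against compound 2 the change is cyano in place of benzoyl on a double-bonded chain carbon bound to a double-bonded chain carbon and a sulfonyl sulfur. Compound 3 also carries the cyano on a double-bonded chain carbon bound to a sulfonyl sulfur, and its number is far below that of compound 2, though compound 3 differs from compound 2 in more than this one place, so the comparison is only a pointer.

A step downward is expected, beyond the scatter, with a 26-fold lower number from compound 2 to compound 4 (1.42 log units; beyond the scatter) as the estimated size, because compound 3 with its cyano gives 538 nM. For compound 4 the expected value is 1500 nM, with a range from 400 nM to 6000 nM.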

Compound 4, concentration for 50% growth inhibition: 23600 nM
For compound 4 the middle estimate is 16-fold (1.20 log units) below the measured one; the measured number lies above the stated range.
By their numbers in this assay, from the lowest: compound 3; then compound 1; then compounds 4 and 2 (each within the scatter of the next).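

In this assay, replacing benzoyl with cyano on the double-bonded chain carbon bound to a double-bonded chain carbon and a sulfonyl sulfur gives a 1.7-fold lower number from compound 2 to compound 4 (0.22 log units; within the scatter), so on this core the position accepts the loss of a ring and a drop from 8 heavy atoms to 2 without a change that can be read. Cyano on this core therefore does not by itself give a number like that of compound 3 at 538 nM, and the features behind that value cannot be separated, as compound 3 differs from compound 4 in more than one place. No measurement shown bears on the reason for this result.

The two groups compared here leave open whether a carboxylic acid, an amine or a longer chain at this position would give a number outside the scatter of compound 2 and compound 4. Also open, from the compounds shown here alone, is how much each of the other structural differences of compound 3 contributes on its own, which would take compounds differing from compound 4 in only one of those places.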